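A few compounds are considered here, and "the series" means these few. Any claim that something is new, unique, unknown or untested is made for them only; others in the source may bear on it.

Measured compounds:
compound 1 `CC1CCN(C2CCN(S(=O)(=O)c3cccnc3Cl)CC2)CC1` — > 5000 nM
compound 2 `CCc1cc(Br)ccc1S(=O)(=O)N1CCC(N2CCC(C)CC2)CC1` — 0.6 nM
compound 3 `CCCOc1ccc(S(=O)(=O)N2CCC(N3CCC(C)CC3)CC2)cc1` — 452 nM

All three were tested in a functional assay on DLD-1 cells (Homo sapiens) for antiproliferative activity, read by CellTiter-Glo, with a stated time of 72 h; a lower number here means a stronger inhibitor, a higher number a weaker inhibitor. Going by these compounds, compound 1 gives only a limit of the assay, > 5000 nM, so its real value is unknown; it is the one sitting at the limit of > 5000 nM in this assay, at which 1 of the 3 values shown sits. Compound 2 reaches 0.6 nM and compound 3 reaches 452 nM, both proper numbers. The unmeasured compound 4 `Cc1nc(Cl)sc1S(=O)(=O)N1CCC(N2CCC(C)CC2)CC1` differs from compound 1 in one place: 2-chloro-4-methyl-1,3-thiazol-5-yl in place of 2-chloropyridin-3-yl on a sulfonyl sulfur. Among the measured compounds shown here, no measured pair of compounds that differ in a single place exists here, so the size of this step cannot be read from the data, and compound 1 standing at a limit leaves the starting point itself open. Compound 4 is expected at 800 nM, in a range from 60 nM to 5000 nM. That estimate means an expected step of an at least 6.2-fold lower number from compound 1 to compound 4 (0.79 log units; beyond the scatter) in this assay, likely toward stronger inhibition but with wide uncertainty.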

Compound 4, half-maximal inhibitory concentration: 1.6 nM
The estimate for compound 4 lay 500-fold (2.70 log units) above the measured number, outside the stated range (below it).
By their numbers in this assay, from the lowest: compound 2; then compound 4; then compound 3. At a limit, above all of these: compound 1.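

Exchanging 2-chloropyridin-3-yl for 2-chloro-4-methyl-1,3-thiazol-5-yl on a sulfonyl sulfur gives an at least 3100-fold lower number from compound 1 to compound 4 (3.49 log units; beyond the scatter) in this assay. With the rest of the molecule unchanged, this single exchange shows that the group on the sulfonyl sulfur can by itself decide how strongly these compounds inhibit. The step can only be given as a minimum because compound 1 stands at a limit: the limit of > 5000 nM in this assay, at which 1 of the 4 values shown sits.

Going by these compounds, it remains open whether the methyl of the thiazolyl group is needed, and what an amine in place of its chlorine would do.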